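Swapping a furan arm for a fluorinated benzyl arm

This account rests on a few compounds, and the source may have more. Where it says the series, first, only, none or still open, it means among the compounds named here.

Compound 3 `FC(F)(F)c1cccc(Cc2ccc3c(NCCCNCc4ccco4)ccnc3c2)c1` is the weakest performer of the three compounds measured in an ADME assay for permeability, using PAMPA, with a stated time of 30 min, at pH 7.4; a higher number here means that the compound crosses the layer faster, a lower number that the compound crosses the layer more slowly: compound 3 gives 23 10^-6 cm/s. Compound 1 `COc1cccc(Oc2ccc3c(NCCCNCc4cc(F)ccc4OC)ccnc3c2)c1` gives 317 10^-6 cm/s and compound 2 `COc1ccc(F)cc1CNCCCNc1ccnc2cc(-c3ccc(F)cc3)ccc12` gives 237 10^-6 cm/s, both well above compound 3 beyond the scatter. Among the compounds with values here, the only measured step, a 1.3-fold lower number from compound 1 to compound 2 (0.13 log units; within the scatter), concerns a change on the shared core and does not touch the part altered here. Compound 4 `COc1ccc(F)cc1CNCCCNc1ccnc2cc(Cc3cccc(C(F)(F)F)c3)ccc12` differs from compound 3 by 5-fluoro-2-methoxyphenyl in place of furan-2-yl on a saturated chain carbon bound to an amine nitrogen. Compound 4 thus carries the same arm on the amine nitrogen as compounds 1 and 2, while keeping the core substituent of compound 3. Within the data shown here, no measured step shows this arm change by itself, so its effect is uncertain. Given that compound 2, which shares that arm, gives 237 10^-6 cm/s, a modest rise is expected, estimated as a 2.2-fold higher number from compound 3 to compound 4 (0.34 log units; beyond the scatter). Compound 4 is therefore expected to give about 50 10^-6 cm/s, within a range from 15 10^-6 cm/s to 170 10^-6 cm/s.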

Compound 4, apparent permeability in the ADME assay: 23 10^-6 cm/s
Compound 4: middle estimate off by 2.2-fold (0.34 log units), on the high side, within the range that was stated.
By their numbers in the ADME assay, from the lowest: compounds 3 and 4 (each within the scatter of the next); then compounds 2 and 1 (each within the scatter of the next).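

In the ADME assay the arm swap alone gives no change at the digits printed from compound 3 to compound 4 (within the scatter), so with 3-(trifluoromethyl)benzyl on the shared core, furan-2-yl and 5-fluoro-2-methoxyphenyl on the saturated chain carbon bound to an amine nitrogen cannot be told apart. The large steps come instead from the group on the aromatic carbon: with the 5-fluoro-2-methoxybenzyl arm held fixed, there is a 10-fold lower number from compound 2 to compound 4 (1.01 log units; beyond the scatter) and a 14-fold lower number from compound 1 to compound 4 (1.14 log units; beyond the scatter) when 3-(trifluoromethyl)benzyl enters. In a physicochemical assay for solubility, with a stated time of 18 h, at pH 7.4 (on this read-out higher numbers stand for higher solubility and lower numbers for lower solubility), compound 3 gives 4200 nM and compound 4 gives 4200 nM, which is no change at the digits printed from compound 3 to compound 4 (within the scatter) as well.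

No measurement at hand explains these results. As far as these compounds go, whether a carboxylic acid on the arm would shift either read-out, and whether furan-2-yl would also match 5-fluoro-2-methoxyphenyl with 4-fluorophenyl or 3-methoxyphenoxy on the core, stays open.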